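The compounds below may be only part of what the source reports. "The series", "measured", "known", "first", "only" and "open" are said of these compounds alone.

Compound 1 `CCOC(=O)C1=C(C)N/C(=C/c2cc(C)n(-c3cccc(OC)c3)c2C)C1=O` in a physicochemical assay for lipophilicity, read by HPLC, at pH 7.4; a higher number here means a more lipophilic compound, a lower number a more polar compound: 2.9
Compound 2 `CCOC(=O)C1=C(C)N/C(=C/c2cc(C)n(-c3cccc(O)c3)c2C)C1=O` in this assay: "not determined" (no result reported)

Compound 2 stands without a number in this assay; no result was obtained for it, so it cannot be placed against compound 1, whose reading in this assay is 2.9. The step from compound 2 to compound 3 `CCOC(=O)C1=C(C)N/C(=C/c2cc(C)n(-c3ccncc3)c2C)C1=O` brings (pyridin-4-yl in place of 3-hydroxyphenyl on an aromatic nitrogen). Among the compounds with values here, with no measured pair of this kind to lean on, the size of the step in this assay is not known from the data, and the only anchor is compound 1. The expectation is that compound 3 reads lower than compound 1 in this assay by more than the usual scatter, though this rests on one neighbouring reading rather than on a step between measured compounds. Compound 3 is therefore estimated to give 1.8 in this assay, within a range from 1.2 to 2.5.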

Compound 3, distribution coefficient: 3.2
Estimate against measurement, compound 3: 1.40 log units below; the measured number lies above the stated range.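

In this assay, exchanging the 3-methoxyphenyl on the aromatic nitrogen for pyridin-4-yl gives a number 0.30 log units higher from compound 1 to compound 3 (within the scatter), so this pair of compounds cannot be told apart in the read-out. At this position, then, a six-membered aromatic ring with a hetero atom can stand in for a methoxy-bearing ring of carbon only without a change beyond the scatter, while the step from compound 2 cannot be read, since compound 2 has no number. Nothing at hand accounts for this result.

This rests on a single pair, so it does not show how far the finding reaches at this nitrogen. Open too, from the compounds shown here alone, is how an unsubstituted phenyl, a phenyl carrying a carboxylic acid or a saturated piperidin-4-yl would read here.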